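Furanyl for phenyl on a shorter-linked coumarin-triazole chalcone

The compounds below may be only part of what the source reports. "The series", "measured", "known", "first", "only" and "open" are said of these compounds alone.

Three compounds share a dienone chain carrying a methoxy-substituted aryl ring that is tethered through a triazole to a coumarin. Compound 1 `COc1cc(/C=C/C(=O)/C=C/c2ccccc2)ccc1OCc1cn(CCCCOc2cc(=O)oc3ccccc23)nn1` gives 34% in a functional assay on HCT-116 cells (Homo sapiens) for inhibition, read by sulforhodamine B assay, with a stated time of 48 h, tested at 50 uM; a lower number here means less inhibition of growth, a higher number more inhibition of growth at the concentration tested. Compound 2 `COc1cc(/C=C/C(=O)/C=C/c2ccco2)ccc1OCc1cn(CCCCOc2cc(=O)oc3ccccc23)nn1` gives 47% in this assay. Within the data shown here, the single change between them, (furan-2-yl in place of phenyl on a double-bonded chain carbon bound to a double-bonded chain carbon), produced a number 13 percentage points higher from compound 1 to compound 2 (beyond the scatter). Compound 3 `COc1cc(/C=C/C(=O)/C=C/c2ccccc2)ccc1OCc1cn(CCOc2cc(=O)oc3ccccc23)nn1` gives 56% in this assay; its number sits within the scatter of that of compound 2 and beyond the scatter of that of compound 1. The difference between the cores of compound 3 and compound 1 is not broken down here.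

Compound 4 `COc1cc(/C=C/C(=O)/C=C/c2ccco2)ccc1OCc1cn(CCOc2cc(=O)oc3ccccc23)nn1` has not yet been measured in this assay. It differs from compound 3 by furan-2-yl in place of phenyl on a double-bonded chain carbon bound to a double-bonded chain carbon, the same change that turned compound 1 into compound 2, made at the same place. Beside the earlier step of a number 13 percentage points higher from compound 1 to compound 2 (beyond the scatter), the expected step from compound 3 is a number 10 percentage points higher from compound 3 to compound 4 (within the scatter), resting on that one measured pair alone. Compound 4 is therefore estimated at 66% in this assay, expected to fall between 50% and 80%.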

Compound 4, percent growth inhibition at one concentration: 72%
Beside the measured number, compound 4's estimate is 6 percentage points below it; low and high end bracket the measured number.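

In this assay, furan-2-yl in place of phenyl gave a number 16 percentage points higher from compound 3 to compound 4 (beyond the scatter), and this step can be set against the same change on the other core: the same change on two cores in this assay, a number 13 percentage points higher (beyond the scatter) from compound 1 to compound 2 and a number 16 percentage points higher (beyond the scatter) from compound 3 to compound 4, 3 percentage points apart, within the scatter of two such steps. On these two cores, then, the change carried over in the same direction, and its size did not differ between them beyond the scatter. Among these compounds, this rests on only two pairs, read at a single concentration in one kind of cell, so it shows neither that the step would hold on any other core nor why the change raises growth inhibition.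

The compounds shown leave open whether the gain is particular to furan-2-yl or would also come with another ring at that place, such as thiophen-2-yl or pyridin-3-yl, or with a phenyl carrying an amine or a carboxylic acid. They also leave open whether the step would persist on a core with a longer chain than those present here.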